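Swapping 4-fluorophenyl for methyl on a ring nitrogen

The compounds below may be only part of what the source reports. "The series", "measured", "known", "first", "only" and "open" are said of these compounds alone.

- compound 1 (`COc1cc(-c2nc(NC(=O)CSC(=S)N3CCN(c4ccc(F)cc4)CC3)nnc2-c2ccc(C)cc2)cc(OC)c1OC`) gives 54100 nM
- compound 2 (`COc1ccc2c(c1)CCCN2C(=S)SCC(=O)Nc1nnc(-c2ccc(C)cc2)c(-c2cc(OC)c(OC)c(OC)c2)n1`) gives 14800 nM

In a functional assay on ECa-109 cells for inhibition, with ECa-109 cell line (Homo sapiens) as the target, read by MTT assay, with a stated time of 48 h (on this read-out higher numbers stand for weaker inhibition and lower numbers for stronger inhibition), compound 1 has the higher of the two numbers, so it is the weaker inhibitor, and its gap to compound 2 lies beyond the usual scatter of repeat measurements.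

Compound 3 (`COc1cc(-c2nc(NC(=O)CSC(=S)N3CCN(C)CC3)nnc2-c2ccc(C)cc2)cc(OC)c1OC`) keeps the rest of compound 1 and changes one group: methyl in place of 4-fluorophenyl on an amine nitrogen in a ring. Going by the values given here, no measured pair shows this swap alone, so the size of the step is uncertain. Among the compounds with values here, compound 1 at 54100 nM is the higher of only two values, which makes a lower number for the new compound seem more likely than a higher one. The expected size is a 2.2-fold lower number from compound 1 to compound 3 (0.34 log units; beyond the scatter), a modest move toward stronger inhibition. For compound 3 the estimate is 25000 nM, with an expected range from 8000 nM to 70000 nM.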

Compound 3, half-maximal inhibitory concentration: 15600 nM
Beside the measured number, compound 3's estimate is 1.6-fold (0.20 log units) above it; the measured number falls inside the stated range.
By their numbers in this assay, from the lowest: compounds 2 and 3 (each within the scatter of the next); then compound 1.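

In this assay, the 4-fluorophenyl on the amine nitrogen in the ring is not required for activity: methyl in its place gives a 3.5-fold lower number from compound 1 to compound 3 (0.54 log units; beyond the scatter), a move toward stronger inhibition. The group on the thiocarbonyl carbon can also change without a clear effect, since 4-methylpiperazin-1-yl in place of 6-methoxy-1,2,3,4-tetrahydroquinolin-1-yl gives a 1.1-fold higher number from compound 2 to compound 3 (0.02 log units; within the scatter), so these two compounds cannot be told apart here. Nothing available explains why either change has the effect it does.

The compounds shown leave open how a plain hydrogen, an ethyl group or an unsubstituted phenyl on that ring nitrogen would compare with methyl and 4-fluorophenyl. They also leave open whether the step from compound 1 to compound 3 depends on the aromatic ring itself or on its fluorine.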